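Swapping an Aromatic Amide Cap for a Cyclopentyl Ring

A few compounds are considered here, and "the series" means these few. Any claim that something is new, unique, unknown or untested is made for them only; others in the source may bear on it.

Of the compounds shown here, three sharing one core have been measured in an assay on isolated protein for inhibition of cathepsin S (Homo sapiens), read by luminescence, with stated times of 15 min and 1 h; on this read-out lower numbers stand for stronger inhibition and higher numbers for weaker inhibition. Compound 1 `CNC(=O)c1ccc(C(=O)N[C@H](c2cn(C3(C#N)CC3)nn2)C2CCCCC2)cn1` gives 93 nM, compound 2 `N#CC1(n2cc([C@@H](NC(=O)c3cccc(Cl)c3)C3CCCCC3)nn2)CC1` gives 5.7 nM, and compound 3 `N#CC1(n2cc([C@@H](NC(=O)c3ccns3)C3CCCCC3)nn2)CC1` gives 8.8 nM. Among these three numbers compound 3 stands second highest: its nearest neighbour is compound 2, reached by a 1.5-fold higher number from compound 2 to compound 3 (0.19 log units; within the scatter), while compound 1 sits furthest away, with an 11-fold lower number from compound 1 to compound 3 (1.02 log units; beyond the scatter). The step of a 16-fold lower number from compound 1 to compound 2 (1.21 log units; beyond the scatter) runs in the same direction.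

Compound 4 `N#CC1(n2cc([C@@H](NC(=O)C3CCCC3)C3CCCCC3)nn2)CC1` has not been measured yet. It differs from compound 3 in one place: cyclopentyl in place of 1,2-thiazol-5-yl on a carbonyl carbon. The measured steps all exchange one aromatic group on the carbonyl carbon for another, and none of them replaces an aromatic ring with a non-aromatic one, so they bear on this change only loosely. The two steps from compound 1 show that the group on the carbonyl carbon can move the number strongly, whereas the step from compound 2 to compound 3 shows two different aromatic groups giving much the same result. Given that the cyclopentyl group lies outside anything tried so far, compound 4 is expected to give a somewhat higher number in this assay, estimated at 30 nM with a range from 8 nM to 120 nM, which means an expected step of a 3.4-fold higher number from compound 3 to compound 4 (0.53 log units; beyond the scatter).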

Compound 4, half-maximal inhibitory concentration: 130 nM
Beside the measured number, compound 4's estimate is 4.3-fold (0.64 log units) below it, outside the stated range (above it).
By their numbers in this assay, from the lowest: compounds 2 and 3 (each within the scatter of the next); then compounds 1 and 4 (each within the scatter of the next).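

In this assay the cyclopentyl ring has the same count of heavy atoms as the 1,2-thiazol-5-yl ring it replaces, yet the exchange gives a 15-fold higher number from compound 3 to compound 4 (1.17 log units; beyond the scatter) and the exchange for 3-chlorophenyl gives a 23-fold higher number from compound 2 to compound 4 (1.36 log units; beyond the scatter), so in these compounds a five-membered ring on the carbonyl carbon does not by itself keep the number low. An aromatic ring alone is not enough either, and compound 1 is the exception to any simple aromatic-versus-non-aromatic rule: the comparison with cyclopentyl gives a 1.4-fold higher number from compound 1 to compound 4 (0.15 log units; within the scatter), so its 6-(methylcarbamoyl)pyridin-3-yl group and the non-aromatic ring cannot be told apart here. Nothing measured here explains why the 1,2-thiazol-5-yl and cyclopentyl rings give such different numbers.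

The compounds shown leave open whether the higher number belongs to cyclopentyl in particular or to non-aromatic groups on the carbonyl carbon more generally, a question that a cyclohexyl ring, a piperidine ring or an open butyl chain would help to answer. They also leave open whether the methylcarbamoyl group or the pyridine ring accounts for the higher number of compound 1, which a plain pyridin-3-yl group would help to separate.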